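Acid Surrogates on a Shared Core at the Angiotensin Receptor

The compounds below may be only part of what the source reports. "The series", "measured", "known", "first", "only" and "open" are said of these compounds alone.

Three compounds were examined in an assay on HEK293 cells for displacement of a labelled ligand from Type-2 angiotensin II receptor (Homo sapiens), tested at 1 uM; on this read-out lower numbers stand for a weaker effect and higher numbers for a stronger effect at the one concentration tested:
compound 1, `CC[C@H](C)[C@H](NC(=O)c1cccc(Cn2ccnc2)c1)C(=O)NO`, gives "not active" (no number reported);
compound 2, `CC[C@H](C)[C@H](NC(=O)c1cccc(Cn2ccnc2)c1)C(=O)NC#N`, gives 6%;
compound 3, `CCCCS(=O)(=O)NC(=O)[C@@H](NC(=O)c1cccc(Cn2ccnc2)c1)[C@@H](C)CC`, gives "not determined" (no result reported).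

Compound 3 therefore stands without a number of its own, and it shares that position with one further entry, compound 1, which also carries no number. Among the compounds with values here, the single number among the three belongs to compound 2, and it is small. Compound 4, `CC[C@H](C)[C@H](NC(=O)c1cccc(Cn2ccnc2)c1)c1nn[nH]n1`, differs from compound 3 by 2H-tetrazol-5-yl in place of (butylsulfonyl)carbamoyl on a saturated chain carbon bound to an amide-type nitrogen and a saturated chain carbon. Within the data shown here, with no measured step to rest on, the author expects no change beyond the usual scatter of this assay, and a weak reading like that of compound 2. Compound 4 is estimated at 10%, with a range from 0% to 35%.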

Compound 4, a percentage reported as inhibition, at one concentration (the size of the read-out at that concentration, not a potency): "not active" (no number reported)
For compound 4 the study gives words and no number; there is nothing to compare the estimate with.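

Within the data shown here, compound 3 and compound 4 offer no pair of numbers, so no step can be read between them. No supporting evidence bears on this result. The compounds shown leave open how (butylsulfonyl)carbamoyl and 2H-tetrazol-5-yl compare on the shared core.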